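A few compounds are considered here, and "the series" means these few. Any claim that something is new, unique, unknown or untested is made for them only; others in the source may bear on it.

Measured so far in a functional assay on Raji cells (Homo sapiens) for cytotoxicity, with a stated time of 72 h; on this read-out lower numbers stand for an effect already at smaller amounts and higher numbers for an effect only at larger amounts of compound:
- compound 1 `C=C[C@@](C)(/C=C/c1ccc(O)c(C=O)c1)CCC=C(C)C` gives > 26000 nM
- compound 2 `C=C[C@@](C)(/C=C/c1ccc(O)c(/C=C/C(=O)O)c1)CCC=C(C)C` gives > 26000 nM
- compound 3 `C=C[C@@](C)(/C=C/c1ccc(O)c(/C=C/C(N)=O)c1)CCC=C(C)C` gives > 26000 nM

Each of these entries is a limit and not a number. Compound 3 therefore has no position within the series beyond its limit of > 26000 nM. Among the compounds with values here, the series so far offers only (the limit of > 26000 nM in this assay, at which 3 of the 3 values shown sit).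

The next compound is compound 4 `C=C[C@@](C)(/C=C/c1ccc(O)c(/C=C(\C)C(=O)OCC)c1)CCC=C(C)C`, with 2-(ethoxycarbonyl)prop-1-en-1-yl in place of 2-carbamoylethenyl on an aromatic carbon, ortho to a hydroxy group: 2-(ethoxycarbonyl)prop-1-en-1-yl in place of 2-carbamoylethenyl on an aromatic carbon.

The measured steps that bear on this change all involve the same aromatic carbon or the carbonyl end of its chain. They are a step that the two limits leave unreadable from compound 1 to compound 2, a step that the two limits leave unreadable from compound 1 to compound 3 and a step that the two limits leave unreadable from compound 2 to compound 3. None of them gives a size, so neither a size nor a direction carries over to this assay, and compound 4 is most likely to be reported as a limit again.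

The expected step is a step that the limit leaves unreadable from compound 3 to compound 4.

The estimate for compound 4 is 30000 nM, with an expected range of 10000 nM to 60000 nM.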

Compound 4, half-maximal effective concentration: > 26000 nM
Compound 4: no number, only a limit (the forecaster's own chance of this, stated with the estimate: 75%); the middle value lies beyond the limit too.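

In this assay compound 4 gives > 26000 nM, which is a limit and not a number, so its steps from compound 1, compound 2 and compound 3 cannot be read. The compounds shown leave open whether any group on this aromatic carbon gives a measurable effect on the shared core: the limit of > 26000 nM in this assay, at which 4 of the 4 values shown sit.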